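This account rests on a few compounds, and the source may have more. Where it says the series, first, only, none or still open, it means among the compounds named here.

Measured in a functional assay on A2780 cells (Homo sapiens) for cytotoxicity, read by MTT assay, with a stated time of 72 h; on this read-out higher numbers stand for weaker inhibition of growth and lower numbers for stronger inhibition of growth:
- Compound 1 `N#C/C(=C/c1ccc(Cl)cc1)C(=O)c1ccc[nH]1`: 75000 nM
- Compound 2 `N#C/C(=C/c1ccc([N+](=O)[O-])cc1)C(=O)c1ccc[nH]1`: 19000 nM
- Compound 3 `N#C/C(=C/c1ccc(O)cc1)C(=O)c1ccc[nH]1`: < 10000 nM (a limit)

For compound 3, this assay gives no exact number, only the limit < 10000 nM. Its place among the three therefore rests on two floors. One is an at least 7.5-fold lower number from compound 1 to compound 3 (0.87 log units; beyond the scatter), which replaces chloro with hydroxy. The other is an at least 1.9-fold lower number from compound 2 to compound 3 (0.27 log units; that floor lies within the scatter), which replaces nitro with hydroxy.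

Compound 4 `COc1ccc(/C=C(/C#N)C(=O)c2ccc[nH]2)cc1` differs from compound 3 by methyl in place of hydrogen on an oxygen on an aromatic ring, so hydroxy to methoxy. For the measured compounds named here, no measured step makes this change. The nearest evidence comes from exchanges of the group on the aromatic carbon, which also include a 3.9-fold lower number from compound 1 to compound 2 (0.60 log units; beyond the scatter).

Both compound 1 and compound 2 carry a group other than hydroxy, and neither has a number under the limit of compound 3. A modest step towards a higher number is therefore expected on losing the hydroxy group, though a step within the scatter remains possible given the floor of an at least 1.9-fold lower number from compound 2 to compound 3 (0.27 log units; that floor lies within the scatter). The estimated change is an at least 1.5-fold higher number from compound 3 to compound 4 (0.17 log units; that floor lies within the scatter). For compound 4 the expected value is 15000 nM, with an estimated range from 4000 nM to 50000 nM.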

Compound 4, concentration for 50% growth inhibition: < 10000 nM
Compound 4: no number, only a limit; the forecaster's own chance of this, stated with the estimate: 15%; at least 1.5-fold (0.17 log units) between middle value and limit.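

With methyl in place of hydrogen on the oxygen on the aromatic ring, compound 4 gives < 10000 nM in this assay, which is a limit, so the hydroxy hydrogen is not required to reach this limit. Methoxy in place of chloro on the aromatic carbon gives an at least 7.5-fold lower number from compound 1 to compound 4 (0.87 log units; beyond the scatter), and methoxy in place of nitro gives an at least 1.9-fold lower number from compound 2 to compound 4 (0.27 log units; that floor lies within the scatter), so methoxy now stands with hydroxy on the same side of the limit, and only the step from chloro is beyond the scatter. The step from compound 3 to compound 4 cannot be read, because both values are limits: the limit of < 10000 nM in this assay, at which 2 of the 4 values shown sit.

On these data alone, how far compound 3 and compound 4 each lie from that limit stays open, so it cannot be said whether the methyl changes the number at all. The compounds shown also leave open how an ethyl group or a longer chain on this oxygen would read, or an amine on the aromatic carbon in place of the hydroxy group.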